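A few compounds are considered here, and "the series" means these few. Any claim that something is new, unique, unknown or untested is made for them only; others in the source may bear on it.

Values in a functional assay on HeLa cells (Homo sapiens) for antiproliferative activity, read by MTT assay, with a stated time of 48 h (a higher number here means a weaker inhibitor, a lower number a stronger inhibitor), follow

- compound 1 (`Brc1ccc(CSc2nnc(-c3cnccn3)s2)cc1`) : 12400 nM
- compound 2 (`Clc1cccc(CSc2nnc(-c3cnccn3)n2-c2ccccc2)c1`) : 13500 nM
- compound 3 (`Fc1ccc(CSc2nnc(-c3cnccn3)n2-c2ccccc2)cc1`) : 7300 nM

Compound 3 gives the lowest number shown (7300 nM), but it lies within the scatter of both compound 1 and compound 2, so the three values cannot be ranked.

The next compound is compound 4 (`c1ccc(CSc2nnc(-c3cnccn3)n2-c2ccccc2)cc1`), which has hydrogen in place of fluoro on an aromatic carbon, para to a large group. The difference from compound 3 is hydrogen in place of fluoro on an aromatic carbon and reads as 4-fluorophenyl to phenyl, or 4-fluorobenzyl to benzyl.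

Among the measured compounds shown here, only one measured step involves this aromatic ring: a 1.8-fold lower number from compound 2 to compound 3 (0.27 log units; within the scatter). That step stays within the scatter, but it exchanges one halogen-bearing ring for another and does not remove the halogen. For the measured compounds named here, no measured pair shows the loss of fluoro directly, so the evidence is thin. On this basis, no step beyond the scatter is expected in this assay, and the direction is left open. The estimated change is a 1.3-fold higher number from compound 3 to compound 4 (0.11 log units; within the scatter) and is expected to be small.

The estimate for compound 4 is 9500 nM, with an expected range from 4000 nM to 22000 nM.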

Compound 4, half-maximal inhibitory concentration: 35600 nM
The estimate for compound 4 lay 3.7-fold (0.57 log units) below the measured number, outside the stated range (above it).
By their numbers in this assay, from the lowest: compounds 3, 1 and 2 (each within the scatter of the next); then compound 4.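

In this assay, the halogen on the benzyl ring now has a readable effect: a 4.9-fold higher number from compound 3 to compound 4 (0.69 log units; beyond the scatter) marks the change from 4-fluorobenzyl to benzyl, and a 2.6-fold higher number from compound 2 to compound 4 (0.42 log units; beyond the scatter) marks the loss of chloro from the 3-chlorophenyl ring. The earlier exchange of one halogen-bearing ring for another gave only a 1.8-fold lower number from compound 2 to compound 3 (0.27 log units; within the scatter), so it could not separate the two halogens, whereas among compound 2, compound 3 and compound 4 the ring without a halogen gives the highest number, and none of the three goes against this. Nothing measured here accounts for these steps.

The compounds shown leave open whether the lower numbers depend on a halogen as such, since a methyl, methoxy or amine group on the aromatic carbon para to a large group would test this against fluoro. They also leave open whether chloro or bromo at that same place would match fluoro on this core, and whether a longer chain between the sulfur and the aromatic ring would keep the difference between halogen-bearing and bare rings.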